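Swapping a benzylsulfonyl group for a sulfamoyl group

The source may report more compounds than this note shows. Statements on the series, on what has been measured and on what is new or still open speak of the compounds shown alone.

Compound 1 `Cc1ccc(S(=O)(=O)Cc2ccccc2)cc1C#Cc1cc(Cl)ccc1OCC(=O)O`: 5 nM
Compound 2 `CC1(O)c2ccc(C#Cc3cc(Cl)ccc3OCC(=O)O)cc2S(=O)(=O)C1(C)C`: 28 nM
Compound 3 `N#Cc1ccc(OCC(=O)O)c(C#Cc2ccccc2Cl)c1`: 24 nM

All three compounds were tested in an assay on CHO cells for displacement of a labelled ligand from prostaglandin D2 receptor 2 (Homo sapiens), read by scintillation counting; a lower number here means a stronger inhibitor, a higher number a weaker inhibitor. Among them compound 1 gives the lowest number, and both compound 2 and compound 3 lie above it by more than the usual scatter, so compound 1 is the strongest inhibitor of the three measured compounds.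

Compound 4 `Cc1ccc(S(=O)(=O)N(C)C(C)C)cc1C#Cc1cc(Cl)ccc1OCC(=O)O` has not yet been measured. It keeps the core of compound 1 and differs in one place: isopropyl(methyl)amino in place of benzyl on a sulfonyl sulfur. Among the measured compounds shown here, no pair of measured compounds shows a change of this kind, so the size of the step cannot be read from the data and must be estimated from the structural change alone. A modest weakening is expected, with the step from compound 1 to compound 4 expected at a 2.0-fold higher number from compound 1 to compound 4 (0.30 log units; within the scatter), which sits near the edge of the scatter. Because compound 1 gives 5 nM, compound 4 is estimated at 10 nM, with a likely range from 3 nM to 40 nM.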

Compound 4, inhibition constant: 3.8 nM
Compound 4: the middle estimate sits 2.6-fold (0.42 log units) above what was measured, and the stated range covers the measured number.
By their numbers in this assay, from the lowest: compounds 4 and 1 (each within the scatter of the next); then compounds 3 and 2 (each within the scatter of the next).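

In this assay, placing isopropyl(methyl)amino where benzyl stood on a sulfonyl sulfur gives a 1.3-fold lower number from compound 1 to compound 4 (0.12 log units; within the scatter), so compound 1 and compound 4 cannot be told apart. This position therefore accepts a group with no ring and with a nitrogen attached to the sulfonyl sulfur, and in this one pair the benzyl ring is not needed to keep the number this low. Nothing available explains why the two groups give such similar numbers.

On these data alone, whether a plain amino group or a ring amine such as piperidine on the same sulfonyl sulfur would fall in this range remains open. As far as these compounds go, it is also open whether a benzyl group joined through a sulfonamide nitrogen, which would combine features of both groups, would do the same.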